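Piperazine nitrogen substituents on the shared core

The source may report more compounds than this note shows. Statements on the series, on what has been measured and on what is new or still open speak of the compounds shown alone.

Measured so far:
compound 1 `Cc1cccc2sc(NC(=O)CCN3CCN(C(C)(C)C)CC3)nc12` — 147 nM
compound 2 `Cc1cccc2sc(NC(=O)CCN3CCN(CC4CCCCC4)CC3)nc12` — 35 nM

In an assay on membranes from brain for displacement of a labelled ligand from Sigma non-opioid intracellular receptor 1 (Cavia porcellus), read by scintillation counting, with a stated time of 120 min (a higher number here means a weaker inhibitor, a lower number a stronger inhibitor), compound 1 gives 147 nM, the highest of the two numbers; its nearest neighbour is compound 2, which in this assay gives 35 nM. Among the measured compounds shown here, the single measured step is a 4.2-fold lower number from compound 1 to compound 2 (0.62 log units; beyond the scatter), a change of group on the amine nitrogen in the ring.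

Compound 3 `Cc1cccc2sc(NC(=O)CCN3CCN(CCN(C(C)C)C(C)C)CC3)nc12` is not yet measured. It differs from compound 1 by 2-(diisopropylamino)ethyl in place of tert-butyl on an amine nitrogen in a ring.

The step from compound 1 to compound 2 is the only one that bears on this change: it exchanges the same tert-butyl on the same ring nitrogen for a larger group and lowers the number beyond the scatter. The entering 2-(diisopropylamino)ethyl is likewise larger than tert-butyl, though it is not cyclohexylmethyl, so the size of the step is uncertain. A lower number than compound 1 is expected, of roughly the size seen to compound 2, as a 2.9-fold lower number from compound 1 to compound 3 (0.47 log units; beyond the scatter). Compound 3 is therefore estimated at 50 nM in this assay, in the range 15 nM to 180 nM.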

Compound 3, inhibition constant: 809 nM
Estimate against measurement, compound 3: 16-fold (1.21 log units) below; measured number outside the range, above it.
By their numbers in this assay, from the lowest: compound 2; then compound 1; then compound 3.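

In this assay, a change away from tert-butyl on this amine nitrogen in a ring does not move the number in one direction: cyclohexylmethyl lowered it, whereas 2-(diisopropylamino)ethyl gives a 5.5-fold higher number from compound 1 to compound 3 (0.74 log units; beyond the scatter), so a larger group at this position does not by itself predict a lower number. The choice of large group matters more here than either departure from tert-butyl, with a 23-fold higher number from compound 2 to compound 3 (1.36 log units; beyond the scatter) exceeding both single steps away from compound 1. Nothing available explains why 2-(diisopropylamino)ethyl raises the number.

The compounds shown do not separate the contribution of the nitrogen in 2-(diisopropylamino)ethyl from that of its chain or its isopropyl groups, as compound 3 introduces these features together. Still open, going by these compounds, is how the number would respond to an all-carbon chain of similar length, or to a smaller amine such as 2-(dimethylamino)ethyl, either of which would help show whether the added nitrogen or the bulk of the diisopropylamino end goes with the higher number.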